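The compounds below may be only part of what the source reports. "The series", "measured", "known", "first", "only" and "open" are said of these compounds alone.

In a functional assay on NCI-H322M cells (Homo sapiens) for inhibition (on this read-out higher numbers stand for weaker inhibition of growth and lower numbers for stronger inhibition of growth), compound 1 `COc1cc(/C=C/C(=O)c2cccc(-n3cc(-c4ccc(Cl)cc4)[nH]c3=O)c2)cc(OC)c1OC` gives 12900 nM. That number lies within the usual scatter of compound 3 `O=C(/C=C/c1cccc(O)c1)c1cccc(-n2cc(-c3ccccc3)[nH]c2=O)c1`, which gives 10600 nM. Compound 2 `COc1cc(/C=C/C(=O)c2cccc(-n3cc(-c4ccccc4)[nH]c3=O)c2)ccc1O` gives 3390 nM, a clearly lower number than either of the other two. The next compound to be read, compound 4 `COc1ccc(-c2cn(-c3cccc(C(=O)/C=C/c4cc(OC)c(OC)c(OC)c4)c3)c(=O)[nH]2)cc1`, keeps the rest of compound 1 and carries methoxy in place of chloro on an aromatic carbon, para to a large group. This is the change from 4-chlorophenyl to 4-methoxyphenyl (methoxy in place of chloro on an aromatic carbon).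

Among the measured compounds shown here, no measured step touches this place. The only one available, a 3.1-fold higher number from compound 2 to compound 3 (0.50 log units; beyond the scatter), is modest and comes from putting 3-hydroxyphenyl in place of 4-hydroxy-3-methoxyphenyl at a different place in the molecule. It shows that the numbers in this small set can move beyond the scatter, but it says nothing about the direction of a swap from chloro to methoxy. No step beyond the scatter is therefore expected in this assay, although the wide range below allows for a move either way. The expected step is a 1.3-fold lower number from compound 1 to compound 4 (0.11 log units; within the scatter). For compound 4 the estimated value is 10000 nM, with an expected range from 3500 nM to 30000 nM.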

Compound 4, concentration for 50% growth inhibition: 2660 nM
For compound 4 the middle estimate is 3.8-fold (0.58 log units) above the measured one; the whole stated range lies above it.
By their numbers in this assay, from the lowest: compounds 4 and 2 (each within the scatter of the next); then compounds 3 and 1 (each within the scatter of the next).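

In this assay, among the compounds shown here, the change from 4-chlorophenyl to 4-methoxyphenyl gives a 4.8-fold lower number from compound 1 to compound 4 (0.69 log units; beyond the scatter), the first measured step at this position. It shows that the group on this aromatic carbon, para to a large group, can by itself move the number beyond the scatter, and that with the rest of compound 1 held fixed, methoxy goes with stronger inhibition of growth than chloro. Nothing given here explains why the number falls with this swap, although the change adds one heavy atom and one hydrogen-bond acceptor by count.

The compounds shown compare only these two groups at this position and on a single background, so it remains open whether the same swap would move the number in the same direction with the 3-hydroxyphenyl of compound 3 or the 4-hydroxy-3-methoxyphenyl of compound 2. They also leave open how an amine, a hydroxy group or a longer chain such as ethoxy at this place would compare with methoxy in this assay.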